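Nitro in Place of Fluoro: an Expected Shift

The source may hold more compounds than are shown below. What is called first, only, known or untested is meant among the compounds shown, and "the series" means these compounds.

compound 1 `CC#CC(CC(=O)O)c1ccc(OCc2ccc(C(=O)N3CCN(c4cccnc4)CC3)s2)cc1` gives 1140 nM in a functional assay on HEK293 cells for agonist activity at Free fatty acid receptor 1 (Homo sapiens), read by fluorescence and calcium flux; a lower number here means that less compound is needed, a higher number that more compound is needed for the effect
compound 2 `CC#CC(CC(=O)O)c1ccc(OCc2ccc(C(=O)N3CCN(c4ccccc4F)CC3)s2)cc1` gives 113 nM in this assay

Compound 2 stands lowest of the two measured numbers in this assay, separated from compound 1 by a 10-fold lower number from compound 1 to compound 2 (1.00 log units; beyond the scatter). Compound 3 `CC#CC(CC(=O)O)c1ccc(OCc2ccc(C(=O)N3CCN(c4ccccc4[N+](=O)[O-])CC3)s2)cc1` differs from compound 2 by nitro in place of fluoro on an aromatic carbon. Within the data shown here, no measured step alters this group; the only step on record, a 10-fold lower number from compound 1 to compound 2 (1.00 log units; beyond the scatter), concerns a different exchange on the same ring and shows only that this position is sensitive. Compound 3 is therefore expected to stay close to compound 2, with a small rise a 2.2-fold higher number from compound 2 to compound 3 (0.34 log units; beyond the scatter), estimated at 250 nM within 70 nM to 900 nM.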

Compound 3, half-maximal effective concentration: 94 nM
Beside the measured number, compound 3's estimate is 2.7-fold (0.42 log units) above it; the range from low to high includes it.
By their numbers in this assay, from the lowest: compounds 3 and 2 (each within the scatter of the next); then compound 1.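

In this assay, nitro in place of fluoro on this aromatic carbon, ortho to a large group, gives a 1.2-fold lower number from compound 2 to compound 3 (0.08 log units; within the scatter), so this position takes three heavy atoms as well as it takes one fluorine. The 2-nitrophenyl in place of pyridin-3-yl gives a 12-fold lower number from compound 1 to compound 3 (1.08 log units; beyond the scatter), which shows that the gain seen with 2-fluorophenyl is not peculiar to fluoro. No evidence at hand explains this tolerance. Still open, on these data alone, is whether a methoxy group or an amine at this place, or a plain phenyl carrying neither, would hold the number at this level.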